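Swapping methoxy for chloro on the shared thiazole-hydrazide scaffold

This account rests on a few compounds, and the source may have more. Where it says the series, first, only, none or still open, it means among the compounds named here.

Measured compounds:
- compound 1, `Cn1nnnc1SCC(=O)N/N=c1/scc(-c2ccc(F)cc2)n1-c1ccccc1`: 113 ug/mL
- compound 2, `COc1ccc(-c2cs/c(=N/NC(=O)CSc3nnnn3C)n2-c2ccccc2)cc1`: 45 ug/mL

Both compounds were tested in an ADME assay on NIH3T3 cells (Mus musculus) for cytotoxicity, read by MTT assay, with a stated time of 24 h; a higher number here means a weaker inhibitor, a lower number a stronger inhibitor. Compound 1 gives 113 ug/mL in this assay, and compound 2 gives 45 ug/mL. For the measured compounds named here, compound 2 therefore stands at the lowest of the two numbers, meaning it is the stronger inhibitor of the pair; its nearest neighbour is compound 1, and the only step between them, a 2.5-fold lower number from compound 1 to compound 2 (0.40 log units; beyond the scatter), is a modest change from a fluoro to a methoxy group.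

Compound 3, `Cn1nnnc1SCC(=O)N/N=c1/scc(-c2ccc(Cl)cc2)n1-c1ccccc1`, has not yet been measured. It differs from compound 2 by chloro in place of methoxy on an aromatic carbon. Going by the values given here, the one step that bears on this change runs the other way: replacing a halogen with methoxy lowered the number. Returning to a halogen, now chloro rather than fluoro, is expected to push the number back up, roughly toward compound 1, giving an estimated step of a 1.8-fold higher number from compound 2 to compound 3 (0.25 log units; within the scatter). Compound 3 is therefore expected to give about 80 ug/mL, with a likely range from 35 ug/mL to 180 ug/mL.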

Compound 3, half-maximal inhibitory concentration: 40 ug/mL
Estimate against measurement, compound 3: 2.0-fold (0.30 log units) above; the range from low to high includes it.
By their numbers in this assay, from the lowest: compounds 3 and 2 (each within the scatter of the next); then compound 1.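

In this assay, chloro and methoxy on an aromatic carbon para to a large group cannot be told apart, with a 1.1-fold lower number from compound 2 to compound 3 (0.05 log units; within the scatter). The earlier compounds shown here could suggest that a halogen at this position gives a higher number than methoxy, but chloro in place of fluoro gives a 2.8-fold lower number from compound 1 to compound 3 (0.45 log units; beyond the scatter), so the two halogens do not behave alike here and compound 3 goes against that reading. Among these three compounds, compound 1 with its fluoro is the one that stands apart, while compound 2 and compound 3 sit together, and nothing available explains why the fluoro compound differs from the other two.

Three groups at one position cannot show what sets the number, or whether compound 1 is an isolated case or part of a wider trend. From the compounds shown here alone, an amine, a carboxylic acid or a longer chain such as ethoxy at this position would test how far the lower numbers of compound 2 and compound 3 extend, and the effect of changes elsewhere on the shared core remains open.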